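Swapping a long chain for fluorine in a fatty acid receptor agonist

The source may hold more compounds than are shown below. What is called first, only, known or untested is meant among the compounds shown, and "the series" means these compounds.

Of the compounds shown here, three have been tested in a functional assay on cells for agonist activity at Free fatty acid receptor 1 (Homo sapiens), read by FLIPR and calcium flux, with a stated time of 60 min; a higher number here means a larger maximal response, a lower number a smaller maximal response. Compound 3 `COc1ccc(CCCC(C)(C)C)c(N2CCC(COc3cccc(C(CC(=O)O)C4CC4)c3)CC2)c1` gives 106%, and compound 2 `COc1ccc(CCCC(C)(C)C)c(-c2ccc(COc3cccc(C(CC(=O)O)C4CC4)c3)cc2)c1` matches it within the usual scatter with 105%. Compound 1 `COc1ccc(F)c(-c2ccc(COc3cccc([C@@H](CC(=O)O)C4CC4)c3)nc2CC(C)(C)C)c1`, which carries a fluoro group and differs at several other places as well, gives 66%, clearly below the other two. Compound 4 `COc1ccc(F)c(N2CCC(COc3cccc(C(CC(=O)O)C4CC4)c3)CC2)c1` is not yet measured; it differs from compound 3 in one place: fluoro in place of 4,4-dimethylpentyl on an aromatic carbon. Among the compounds with values here, since the only compound here that carries fluoro at that position, compound 1, gives 66%, a drop beyond the scatter is expected, and the step of a number 31 percentage points lower from compound 3 to compound 4 (beyond the scatter) is the estimate. Compound 4 is expected to reach 75% in this assay, within 55% to 95%.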

Compound 4, largest response reached (Emax), in percent of the reference or control that the assay uses: 114%
Estimate against measurement, compound 4: 39 percentage points below, outside the stated range (above it).
By their numbers in this assay, from the lowest: compound 1; then compounds 2, 3 and 4 (each within the scatter of the next).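

Putting fluoro in place of 4,4-dimethylpentyl, with 1 heavy atom entering where 7 leave, gives in this assay a step that is a number 8 percentage points higher from compound 3 to compound 4 (within the scatter). On this core, then, the long chain is not required for a maximal response on a level with that of compound 3. Nothing available explains why the response tolerates this swap.

Open, from the compounds shown here alone, is how a methyl group, a shorter chain or an amine would behave on this aromatic carbon. Also open, going by these compounds, is whether fluoro would be tolerated equally on the core of compound 2.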